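Oxime carbamates on the shared core: alkyl for aryl

This account rests on a few compounds, and the source may have more. Where it says the series, first, only, none or still open, it means among the compounds named here.

The series keeps the core of compound 1 `O=C(Nc1ccccc1)O/N=C1\N[C@H](CO)[C@@H](O)[C@H](O)[C@H]1O` and varies only the group on the amide-type nitrogen of the carbamate. In an assay on isolated protein for inhibition of alpha-galactosidase (Coffea arabica) (a higher number here means a weaker inhibitor, a lower number a stronger inhibitor), compound 1 gives > 100000 nM, a limit of the assay and not a number. Compound 2 `O=C(Nc1c(F)cccc1F)O/N=C1\N[C@H](CO)[C@@H](O)[C@H](O)[C@H]1O` carries 2,6-difluorophenyl in place of phenyl. In this assay compound 2 gives > 100000 nM, again a limit. Compound 3 `CSc1ccc(NC(=O)O/N=C2\N[C@H](CO)[C@@H](O)[C@H](O)[C@H]2O)cc1` carries methylsulfanyl on an aromatic carbon. In this assay compound 3 gives > 100000 nM, also a limit. Compound 3 thus stands with the others at the limit of > 100000 nM in this assay, at which 3 of the 3 values shown sit. The steps a step that the two limits leave unreadable from compound 1 to compound 2, a step that the two limits leave unreadable from compound 1 to compound 3 and a step that the two limits leave unreadable from compound 2 to compound 3 cannot be read between two limits.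

Compound 4 `CC(C)(C)NC(=O)O/N=C1\N[C@H](CO)[C@@H](O)[C@H](O)[C@H]1O` differs from compound 3 by tert-butyl in place of 4-(methylsulfanyl)phenyl on an amide-type nitrogen. Among the compounds with values here, none of the measured steps touches an alkyl group, and the three aryl variants all sit at the limit, so neither size nor direction is readable from them. The expected step is a step that the limit leaves unreadable from compound 3 to compound 4, most likely ending again at a limit. Compound 4 is expected at 150000 nM in this assay, within 40000 nM to 1000000 nM.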

Compound 4, half-maximal inhibitory concentration: > 100000 nM
Compound 4: no number, only a limit; the forecaster's own chance of this, stated with the estimate: 80%; the middle value lies beyond the limit too.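

Compound 4 sits at a limit of the assay, as do compound 1, compound 2 and compound 3, so no step among them can be read in this assay: the limit of > 100000 nM in this assay, at which 4 of the 4 values shown sit.

The compounds shown leave open whether any group on the amide-type nitrogen of the shared core gives a measurable value in this assay, and how tert-butyl ranks against the aryl groups.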